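Replacing Neopentyl with Cyclopentenyl on the Shared Core

This account rests on a few compounds, and the source may have more. Where it says the series, first, only, none or still open, it means among the compounds named here.

Compound 1 `CC(C)(C)Cc1nn(CCC2CC2)c(=O)c(C2=NS(=O)(=O)c3cc(NS(C)(=O)=O)ccc3N2)c1O` was examined in an in vitro ADME assay on microsomes from liver (Macaca mulatta) for metabolic stability, tested at 5 uM; a higher number here means that the compound lasts longer, a lower number that the compound disappears faster. In this assay compound 1 reaches > 1 h, which is a limit of the assay and not a number (the limit of > 1 h in this assay, at which 1 of the 2 values shown sits). Compound 2 `CC(C)CCn1nc(CC(C)(C)C)c(O)c(C2=NS(=O)(=O)c3cc(NS(C)(=O)=O)ccc3N2)c1=O` gives 0.533 h in this assay. The step of an at least 1.8-fold lower number from compound 1 to compound 2 (0.27 log units; that floor lies within the scatter) concerns the saturated chain, not the aromatic carbon changed here. Compound 3 `CS(=O)(=O)Nc1ccc2c(c1)S(=O)(=O)N=C(c1c(O)c(C3=CCCC3)nn(CCC3CC3)c1=O)N2` differs from compound 1 by cyclopent-1-en-1-yl in place of neopentyl on an aromatic carbon. Within the data shown here, no measured step touches this aromatic carbon, and compound 1 itself stands only at a limit, so the single measured step gives no guide to the size or direction of the change in this assay. The step of a number no higher from compound 1 to compound 3 (the limit leaves the size open) is therefore expected to stay within the scatter. Compound 3 is estimated at 1 h, with a range from 0.4 h to 2.5 h.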

Compound 3, half-life: 0.683 h
Estimate against measurement, compound 3: 1.5-fold (0.17 log units) above, within the range that was stated.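

Cyclopent-1-en-1-yl in place of neopentyl on this aromatic carbon, the only change at this position among the compounds shown, gives an at least 1.4-fold lower number from compound 1 to compound 3 (0.16 log units; that floor lies within the scatter). Compound 1 gives > 1 h, which is a limit of the assay and not a number: the limit of > 1 h in this assay, at which 1 of the 3 values shown sits. The step therefore fixes only a floor, and with that floor inside the scatter, it shows no firm direction for swapping the open neopentyl chain for this ring of the same heavy-atom count.

On these data alone, how large the step really is stays open, as does whether any difference would follow the ring or its double bond. A saturated cyclopentyl group on the same aromatic carbon would separate those two, and a shorter chain such as ethyl would show how far this position tolerates a smaller group.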